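Chain extension from compound 2 to compound 4

The source may report more compounds than this note shows. Statements on the series, on what has been measured and on what is new or still open speak of the compounds shown alone.

In a functional assay on brain (Rattus norvegicus, strain Wistar) for inhibition (a lower number here means a stronger inhibitor, a higher number a weaker inhibitor), compound 1 `Cc1[nH]c(=O)n(C)c1-c1ccc(OCCC(C)C)cc1` reads 6600 nM and compound 2 `Cc1[nH]c(=O)n(C2CCCCC2)c1-c1ccc(OCCC(C)C)cc1` reads 7200 nM while compound 3 `CCCCCCc1ccc(-c2c(C)[nH]c(=O)n2C2CCCCC2)cc1` reads 13700 nM on the same scale. Compound 2 thus lies within the scatter of both other compounds. Cyclohexyl in place of methyl on an aromatic nitrogen gives a 1.1-fold higher number from compound 1 to compound 2 (0.04 log units; within the scatter) as one step, and hexyl in place of isopentyloxy on an aromatic carbon gives a 1.9-fold higher number from compound 2 to compound 3 (0.28 log units; within the scatter) as the other. Both steps stay within the scatter.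

Compound 4 `CCCCCCCCCCOc1ccc(-c2c(C)[nH]c(=O)n2C2CCCCC2)cc1` is not yet measured. It carries octyl in place of isopropyl on a saturated chain carbon, two bonds along the chain from an oxygen on an aromatic ring. Among the compounds with values here, no measured step lengthens a chain at this place. The hexyl swap (a 1.9-fold higher number from compound 2 to compound 3 (0.28 log units; within the scatter)) is the nearest guide, and the first step bears on a different place. The estimated step in this assay is a 1.2-fold lower number from compound 2 to compound 4 (0.08 log units; within the scatter) and so none beyond the scatter is expected, though with wide uncertainty. For compound 4 the estimated value is 6000 nM within an expected range of 1800 nM to 20000 nM for repeat measurements.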

Compound 4, half-maximal inhibitory concentration: 10500 nM
Compound 4: middle estimate off by 1.8-fold (0.24 log units), on the low side, and the stated range covers the measured number.
By their numbers in this assay, from the lowest: compounds 1, 2, 4 and 3 (each within the scatter of the next, the first and the last beyond it).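

In this assay, within the data shown here, octyl in place of isopropyl on a saturated chain carbon, two bonds along the chain from an oxygen on an aromatic ring, gives a 1.5-fold higher number from compound 2 to compound 4 (0.16 log units; within the scatter) as the only measured step at this place. The same difference read one bond further out is isopentyl to decyl, so among these compounds this place takes the longer chain with the reading of compound 4 staying within the scatter of compound 2. No measurement shown here accounts for this result.

As far as these compounds go, whether an amine or a carboxylic acid at the end of the chain, or a chain shorter than isopentyl, would move the number beyond the scatter remains open. Also open, from the compounds shown here alone, is whether the decyl chain reads the same with methyl in place of cyclohexyl on the aromatic nitrogen.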